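Adding a Methoxy Group to the Only Numbered Compound

The source may hold more compounds than are shown below. What is called first, only, known or untested is meant among the compounds shown, and "the series" means these compounds.

The measured set holds three compounds sharing one core, all tested in a functional assay on A549 cells (Homo sapiens) for inhibition, read by sulforhodamine B assay, with a stated time of 48 h; on this read-out higher numbers stand for lower toxicity in this test and lower numbers for higher toxicity in this test. For the measured compounds named here, compound 1 `COc1ccc(-c2cc(/C=C/C(=O)c3ccc(N)cc3)[nH]n2)cc1` is the only one to give a number: in this assay compound 1 gives 46900 nM. Compound 2 `COc1cc(-c2cc(/C=C/C(=O)c3ccc(Cl)c(Cl)c3)[nH]n2)cc(OC)c1OC` reaches only a limit of the assay, and in this assay compound 2 gives > 100000 nM. Compound 3 `COc1ccc(C(=O)/C=C/c2cc(-c3cc(OC)c(OC)c(OC)c3)n[nH]2)cc1` likewise stops at a limit, and in this assay compound 3 gives > 100000 nM. Going by the values given here, the single change among the measured compounds, 4-methoxyphenyl in place of 3,4-dichlorophenyl on a carbonyl carbon, gives a step that the two limits leave unreadable from compound 2 to compound 3, so its size stays hidden. The measured set shows mainly (the limit of > 100000 nM in this assay, at which 2 of the 3 values shown sit).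

Compound 4 `COc1ccc(-c2cc(/C=C/C(=O)c3ccc(N)cc3)[nH]n2)cc1OC` differs from compound 1 by methoxy in place of hydrogen on an aromatic carbon. Among the compounds with values here, no measured step bears on this change, since the only recorded step compares two limits and cannot be read. Compound 1 is therefore the sole anchor, and most of the known values sit where the assay stops counting. The expected step for compound 4 in this assay is a 1.3-fold higher number from compound 1 to compound 4 (0.11 log units; within the scatter), within the usual scatter and leaning toward lower toxicity. The estimated value for compound 4 is 60000 nM, with a range from 20000 nM to 200000 nM.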

Compound 4, concentration lethal to 50% of the cells: 45200 nM
The estimate for compound 4 lay 1.3-fold (0.12 log units) above the measured number; the range from low to high includes it.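

In this assay, placing methoxy in place of hydrogen on an aromatic carbon gives a 1.0-fold lower number from compound 1 to compound 4 (0.02 log units; within the scatter). For the compounds shown here, this is the first step in the set that can be read, since the only earlier step runs between two limits and cannot be read. It shows that at this position, ortho to a methoxy group and meta to a large group, a methoxy group of 2 heavy atoms leaves compound 1 and compound 4 indistinguishable in this test, so the added group gives no sign here of either raising or lowering the toxicity read-out.

Still open, from the compounds shown here alone, is whether a different group at the same position, such as a hydroxyl, a fluorine atom or an amine, would give a step beyond the scatter, and whether methoxy would behave the same way with another group in place of the 4-aminophenyl on the carbonyl carbon. Any wider reading of the set stays limited, as the remaining values mark where the assay stops counting rather than giving numbers: the limit of > 100000 nM in this assay, at which 2 of the 4 values shown sit.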